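From tert-Butyl to Chloro: Expected Change in Growth Inhibition

The source may report more compounds than this note shows. Statements on the series, on what has been measured and on what is new or still open speak of the compounds shown alone.

For the measured compounds named here, compound 1 `CC(C)(C)c1ccc(SCc2ccc(C(=O)Nc3ccccc3N)cc2)cc1` stands highest of the two compounds measured so far. In a functional assay on HCT-116 cells (Homo sapiens) for inhibition, read by CCK-8 assay, with a stated time of 72 h, tested at 8 uM (on this read-out lower numbers stand for less inhibition of growth and higher numbers for more inhibition of growth at the one concentration tested), compound 1 gives 60.5%. Compound 2 `Nc1ccccc1NC(=O)/C=C/c1ccc(CSc2ccc(C(F)(F)F)cn2)cc1` comes out well lower: in this assay compound 2 gives 14.9%, a gap beyond the usual scatter. Compound 3 `Nc1ccccc1NC(=O)c1ccc(CSc2ccc(Cl)cc2)cc1` has not been measured yet. It differs from compound 1 in one place: chloro in place of tert-butyl on an aromatic carbon. Going by the values given here, no pair of measured compounds shows what such a swap does, so only a modest fall is expected, with the step estimated at a number 15.5 percentage points lower from compound 1 to compound 3 (beyond the scatter). Compound 3 is therefore expected to reach about 45%, within a range from 20% to 70%.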

Compound 3, percent growth inhibition at one concentration: 76.6%
Beside the measured number, compound 3's estimate is 31.6 percentage points below it; measured number outside the range, above it.
By their numbers in this assay, from the lowest: compound 2; then compound 1; then compound 3.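

In this assay, chloro in place of tert-butyl on this aromatic carbon gives a number 16.1 percentage points higher from compound 1 to compound 3 (beyond the scatter). Growth inhibition at this position therefore does not depend on the tert-butyl group: a single chlorine atom can take the place of its four carbons and the number still rises. Nothing measured here bears on why it rises. Going by these compounds, it remains open how a bare hydrogen, an amine or a carboxylic acid would fare at this position. This single pair also cannot establish a general trend for the position.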